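Chain extension from compound 2 to compound 3

The compounds below may be only part of what the source reports. "The series", "measured", "known", "first", "only" and "open" are said of these compounds alone.

For the measured compounds named here, in a physicochemical assay for lipophilicity (a lower number here means a more polar compound, a higher number a more lipophilic compound), compound 1 (`CCOC(=O)c1ccc(S(N)(=O)=O)cc1`) gives 1.17 and compound 2 (`CCCOC(=O)c1ccc(S(N)(=O)=O)cc1`) gives 1.75 as the higher of the two numbers so far. Compound 3 (`CCCCOC(=O)c1ccc(S(N)(=O)=O)cc1`) is still unmeasured. Its change from compound 2 is propyl to butyl (methyl in place of hydrogen on a saturated chain carbon, three bonds along the chain from an oxygen next to a carbonyl group): methyl in place of hydrogen on a saturated chain carbon, three bonds along the chain from an oxygen next to a carbonyl group. Going by the values given here, only one measured step bears on this change: a number 0.58 log units higher from compound 1 to compound 2 (beyond the scatter) for the same replacement two bonds along the chain from that oxygen. One step sets no trend, yet a modest step of similar size and in the same direction is expected in this assay for this change. The estimated step is a number 0.55 log units higher from compound 2 to compound 3 (beyond the scatter) on that reading. Compound 3 is expected at 2.3 with a range from 2.05 to 2.55 around that estimate.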

Compound 3, partition coefficient: 2.34
The estimate for compound 3 lay 0.04 log units below the measured number; the range from low to high includes it.
By their numbers in this assay, from the lowest: compound 1; then compound 2; then compound 3.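

With the methyl now three bonds along the chain from an oxygen next to a carbonyl group, the replacement gives a number 0.59 log units higher from compound 2 to compound 3 (beyond the scatter) in this assay, so a second chain extension moves the number in the same direction as a number 0.58 log units higher from compound 1 to compound 2 (beyond the scatter). Taken together, ethyl in place of hydrogen gives a number 1.17 log units higher from compound 1 to compound 3 (beyond the scatter), so across the ethyl, propyl and butyl members the number rises with each added carbon, and no compound shown goes against this. No measurement bears on why the number moves this way.

From the compounds shown here alone, whether the rise continues with a longer chain such as pentyl or hexyl remains open, as does the effect of branching the chain. The compounds shown also leave open how an amine or a hydroxyl group on the chain would shift the number.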